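The compounds below may be only part of what the source reports. "The series", "measured", "known", "first", "only" and "open" are said of these compounds alone.

Measured in a functional assay on PC-3 cells (Homo sapiens) for inhibition, read by MTT assay, with a stated time of 48 h; a higher number here means a weaker inhibitor, a lower number a stronger inhibitor:

Compound 1 `COc1cc(Nc2nc(Nc3ccc(Cl)cc3)nnc2Cl)cc(OC)c1OC`: 9610 nM
Compound 2 `COc1ccc(Nc2nnc(Cl)c(Nc3cc(OC)c(OC)c(OC)c3)n2)cc1`: 13500 nM
Compound 3 `COc1cc(Nc2nnc(Cl)c(Nc3cc(OC)c(OC)c(OC)c3)n2)cc(OC)c1OC`: 34300 nM

Compound 2, at 13500 nM, holds the middle place among these three numbers. It lies within the scatter of compound 1, so the two cannot be ranked. Compound 3, at 34300 nM, has a clearly higher number than either.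

The next compound to be tested is compound 4 `COc1cc(Nc2nc(Nc3ccc(Br)cc3)nnc2Cl)cc(OC)c1OC`, which departs from compound 2 by a single exchange: bromo in place of methoxy on an aromatic carbon. In words, this is bromo in place of methoxy on an aromatic carbon, turning the 4-methoxyphenyl into a 4-bromophenyl.

Going by the values given here, only one measured step bears on this exchange: a 1.4-fold higher number from compound 1 to compound 2 (0.15 log units; within the scatter). It concerns the same place, with methoxy entering in place of chloro. Read backwards, it shows that removing methoxy there in favour of chloro made no difference beyond the scatter. Among the compounds with values here, no measured compound carries bromo, and no measured step links compound 3 to the others, so the guidance is thin. A slightly lower number is therefore expected, but no shift beyond the scatter.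

The estimated step is a 1.4-fold lower number from compound 2 to compound 4 (0.15 log units; within the scatter). For compound 4 the estimated value is 9500 nM, with an expected range from 4500 nM to 20000 nM.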

Compound 4, half-maximal inhibitory concentration: 8990 nM
Compound 4: middle estimate off by 1.1-fold (0.02 log units), on the high side, and the stated range covers the measured number.
By their numbers in this assay, from the lowest: compounds 4, 1 and 2 (each within the scatter of the next); then compound 3.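

In this assay, the exchange of the 4-methoxyphenyl for a 4-bromophenyl gives a 1.5-fold lower number from compound 2 to compound 4 (0.18 log units; within the scatter), and the exchange of chloro for bromo on the same aromatic carbon gives a 1.1-fold lower number from compound 1 to compound 4 (0.03 log units; within the scatter). Until now, this position had offered a single comparison, between chloro and methoxy; it now offers three among chloro, methoxy and bromo, and every one of them lies within the scatter, so the three compounds cannot be ranked. Across these compounds, then, the swap between a two-atom methoxy and a single halogen atom does not separate the numbers, although all three values remain in the same micromolar-scale band as compound 4 at 8990 nM. Nothing available explains this result or says what lies behind it.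

The compounds shown leave open whether any group at this position could separate the numbers, for instance an amine, a carboxylic acid or a longer alkoxy chain in place of bromo. They also leave open whether the phenyl ring without any group at this position would give a number in the same range.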